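The source may hold more compounds than are shown below. What is called first, only, known or untested is meant among the compounds shown, and "the series" means these compounds.

Compound 1, `COc1cc(-c2nn(-c3cccc(NC(=O)Nc4cc(C(F)(F)F)cc(C(F)(F)F)c4)c3)cc2-c2ccncc2)ccc1Cl`, and compound 2, `O=C(Nc1cccc(-n2cc(-c3ccncc3)c(-c3ccc(Cl)c(O)c3)n2)c1)Nc1cc(C(F)(F)F)cc(C(F)(F)F)c1`, share one core and differ in a single place: hydrogen in place of methyl on an oxygen on an aromatic ring. In a functional assay on DU-145 cells (Homo sapiens) for inhibition, read by sulforhodamine B assay, with a stated time of 48 h (a higher number here means that more compound is tolerated, a lower number that less compound is tolerated), compound 1 gives 21100 nM. In this assay compound 2 gives 17400 nM. The step is a 1.2-fold lower number from compound 1 to compound 2 (0.08 log units; within the scatter), so the two numbers cannot be told apart.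

Compound 3, `COc1cc(-c2nn(-c3cccc(NC(=O)Nc4ccc(Cl)c(C(F)(F)F)c4)c3)cc2-c2ccncc2)ccc1Cl`, carries a different core, and how its core differs from that of compound 1 is not broken down here. For compound 3 in this assay only a limit is known, > 32500 nM, because the limit of > 32500 nM in this assay, at which 1 of the 3 values shown sits, marks the highest concentration that the measurement could report.

Compound 4, `O=C(Nc1cccc(-n2cc(-c3ccncc3)c(-c3ccc(Cl)c(O)c3)n2)c1)Nc1ccc(Cl)c(C(F)(F)F)c1`, has not yet been measured. It stands to compound 3 exactly as compound 2 stands to compound 1: hydrogen in place of methyl on an oxygen on an aromatic ring. The place of the change is the same in both pairs, so this is the same change, made on the core of compound 3 instead of the core of compound 1.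

The expectation for compound 4 rests on this pairing. Because a 1.2-fold lower number from compound 1 to compound 2 (0.08 log units; within the scatter) left the number essentially unchanged, the same change on compound 3 is expected to leave it essentially unchanged as well, that is, an expected step that the limit leaves unreadable from compound 3 to compound 4. Since compound 3 already sits at a limit, compound 4 is expected to give about 38000 nM, between 17000 nM and 90000 nM, and most likely again only a limit rather than a number.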

Compound 4, concentration lethal to 50% of the cells: 25100 nM
Beside the measured number, compound 4's estimate is 1.5-fold (0.18 log units) above it; the measured number falls inside the stated range.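

In this assay, the change from methoxy to hydroxy on the core of compound 3 gives an at least 1.2-fold lower number from compound 3 to compound 4 (0.11 log units; that floor lies within the scatter), and beside the earlier pair the comparison reads: the same change on two cores in this assay, a 1.2-fold lower number (0.08 log units; within the scatter) from compound 1 to compound 2 and an at least 1.2-fold lower number (0.11 log units; that floor lies within the scatter) from compound 3 to compound 4; the limit leaves it open whether they differ For compound 3 the entry > 32500 nM is a limit of the assay and not a number. The two pairs therefore show that the change can be made on both cores and that compound 4 gives a readable number, but they do not show that the change carries from one core to the other with the same effect, since the true size of the second step may be small or considerably larger, and the first step stays within the scatter.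

The compounds shown hold only methoxy or hydroxy at this place on the 4-chloro-3-methoxyphenyl or 4-chloro-3-hydroxyphenyl group, on two cores and in a single cell assay, so they leave open whether the pattern would extend to further cores. They also leave open how the number would respond to an amine, a carboxylic acid or a longer alkoxy chain such as ethoxy in the same place.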